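The source may report more compounds than this note shows. Statements on the series, on what has been measured and on what is new or still open speak of the compounds shown alone.

Measured compounds:
compound 1 `C=C1CC[C@@H]2[C@](C)(COC(C)=O)[C@H](OC(C)=O)CC[C@@]2(C)[C@H]1CC(Nc1ccc(S(=O)(=O)Nc2ccc(Cl)nn2)cc1)C1=CCOC1=O` gives 1680 nM in a functional assay on SK-MEL-28 cells (Homo sapiens) for inhibition, read by sulforhodamine B assay, with a stated time of 48 h; a lower number here means a stronger inhibitor of growth, a higher number a weaker inhibitor of growth
compound 2 `C=C1CC[C@@H]2[C@](C)(COC(C)=O)[C@H](OC(C)=O)CC[C@@]2(C)[C@H]1CC(Nc1ccc(S(=O)(=O)Nc2ncccn2)cc1)C1=CCOC1=O` gives 1690 nM in this assay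

Compound 1 holds the lowest of these two numbers, though the step of a 1.0-fold higher number from compound 1 to compound 2 (0.00 log units; within the scatter) lies within the scatter, so the two compounds cannot be ordered. Compound 3 `C=C1CC[C@@H]2[C@](C)(COC(C)=O)[C@H](OC(C)=O)CC[C@@]2(C)[C@H]1CC(Nc1ccc(S(=O)(=O)Nc2nccs2)cc1)C1=CCOC1=O` differs from compound 1 by 1,3-thiazol-2-yl in place of 6-chloropyridazin-3-yl on a sulfonamide nitrogen. Going by the values given here, the only measured step that bears on this is a 1.0-fold higher number from compound 1 to compound 2 (0.00 log units; within the scatter), a swap of the ring on the same sulfonamide nitrogen, which changed nothing beyond the scatter. Compound 3 is therefore expected to show no step beyond the scatter, a 1.0-fold higher number from compound 1 to compound 3 (0.01 log units; within the scatter). The estimate for compound 3 is 1700 nM, with a range from 800 nM to 3600 nM.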

Compound 3, concentration for 50% growth inhibition: 3950 nM
Estimate against measurement, compound 3: 2.3-fold (0.37 log units) below; the measured number lies above the stated range.
By their numbers in this assay, from the lowest: compounds 1 and 2 (each within the scatter of the next); then compound 3.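

In this assay the ring on the sulfonamide nitrogen proves not to be freely exchangeable: 1,3-thiazol-2-yl gives a 2.4-fold higher number from compound 1 to compound 3 (0.37 log units; beyond the scatter) and a 2.3-fold higher number from compound 2 to compound 3 (0.37 log units; beyond the scatter), a modest loss each time, while the two six-membered rings of compound 1 and compound 2 cannot be told apart. Nothing measured here accounts for this loss. From the compounds shown here alone, whether it goes with the five-membered ring or with the sulfur stays open. So does how an unsubstituted phenyl or an acetyl group on the same nitrogen would compare.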